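Diaryl ether imidazole ureas: aryl change on the urea nitrogen

The compounds below may be only part of what the source reports. "The series", "measured", "known", "first", "only" and "open" are said of these compounds alone.

Measured so far:
- compound 1, `O=C(Nc1ccccc1)Nc1ccc(Oc2ccc(-c3ncc[nH]3)cc2)cc1`: 7.09%
- compound 2, `O=C(Nc1ccc(Oc2ccc(-c3ncc[nH]3)cc2)cc1)Nc1cccc(C(F)(F)F)c1`: 30%

Both numbers come from a functional assay on A549 cells (Homo sapiens) for inhibition, read by MTT assay and WST assay, with a stated time of 72 h, tested at 10 uM; on this read-out higher numbers stand for more inhibition of growth at the one concentration tested and lower numbers for less inhibition of growth. Among the compounds with values here, compound 2 stands highest of the two, with compound 1 as its only neighbour, a step of a number 22.9 percentage points higher from compound 1 to compound 2 (beyond the scatter), brought about by trifluoromethyl in place of hydrogen on an aromatic carbon. Within the data shown here, no other step is known.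

Compound 3, `Cc1ccc(NC(=O)Nc2ccc(Oc3ccc(-c4ncc[nH]4)cc3)cc2)cc1`, differs from compound 2 by 4-methylphenyl in place of 3-(trifluoromethyl)phenyl on an amide-type nitrogen. Among the measured compounds shown here, the one step that bears on it is the hydrogen-to-trifluoromethyl step, a number 22.9 percentage points higher from compound 1 to compound 2 (beyond the scatter), which shows that the aryl group on this nitrogen can move the read-out by a modest amount beyond the scatter. For the measured compounds named here, compound 3 carries neither the bare phenyl of compound 1 nor the trifluoromethyl-bearing ring of compound 2, and no measured compound tells which way a 4-methylphenyl falls between them. The expectation for compound 3 is therefore a step of a number 14 percentage points lower from compound 2 to compound 3 (beyond the scatter), downward, of a size that stays within the span set by compound 1 and compound 2. Compound 3 is estimated at 16% in this assay, with a range from 2% to 34%.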

Compound 3, percent growth inhibition at one concentration: 24.6%
Estimate against measurement, compound 3: 8.6 percentage points below, and the stated range covers the measured number.
By their numbers in this assay, from the lowest: compound 1; then compounds 3 and 2 (each within the scatter of the next).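

In this assay, a second substituted ring on the amide-type nitrogen now stands apart from the bare phenyl of compound 1: a number 17.5 percentage points higher from compound 1 to compound 3 (beyond the scatter), with methyl in place of hydrogen on an aromatic carbon. The rise seen earlier is therefore not confined to trifluoromethyl, and 4-methylphenyl and 3-(trifluoromethyl)phenyl cannot be told apart on this read-out, at a number 5.4 percentage points lower from compound 2 to compound 3 (within the scatter), even though the exchange removes all the fluorine from this ring. Nothing on hand speaks to the reason for either step.

From the compounds shown here alone, whether the group itself or its place on the ring counts stays open, as the two substituted rings differ in both. Also open, going by these compounds, is whether the rise extends beyond these two carbon-attached groups to a ring bearing a methoxy group, a chlorine atom, an amine or a carboxylic acid, and all three compounds remain at modest inhibition at the single concentration tested.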